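Adding a dimethylamino group to compound 3

The compounds below may be only part of what the source reports. "The series", "measured", "known", "first", "only" and "open" are said of these compounds alone.

Measured compounds and their values in an assay on T-REx-293 cells for inhibition of potassium channel subfamily T member 1 (Homo sapiens), read by patch clamp; on this read-out lower numbers stand for stronger inhibition and higher numbers for weaker inhibition:
- compound 1, `Cc1cccc(-c2nnc([C@H](C)NC(=O)c3cc(C4CC4)nn3C)o2)c1`: compound 1 gives > 30000 nM
- compound 2, `Cc1cccc(-n2cc(C(C)NC(=O)c3cc(C(F)(F)F)nn3C)cn2)c1`: compound 2 gives 1600 nM
- compound 3, `C[C@H](NC(=O)c1cc(C(F)(F)F)nn1C)c1nc(-c2ccncc2)no1`: compound 3 gives 5250 nM

The value for compound 1 is a limit of this assay, not a number; it is the limit of > 30000 nM in this assay, at which 1 of the 3 values shown sits. Of the two numbers shown, compound 3 has the higher one, and the nearest is compound 2, whose lower number stands beyond the usual scatter of repeated measurements. All three compounds share the same amide and the same pyrazole carrying a methyl group, and they differ in the ring systems beyond it.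

The next compound is compound 4, `C[C@H](NC(=O)c1cc(C(F)(F)F)nn1C)c1nc(-c2ccnc(N(C)C)c2)no1`. It differs from compound 3 in one place: dimethylamino in place of hydrogen on an aromatic carbon. Within the data shown here, no pair of measured compounds shows what such an addition on this ring does, so there is no measured step to lean on. With nothing to point in either direction, the change from compound 3 to compound 4 is expected to be small, within or only slightly beyond the scatter, and the estimated step is a 1.5-fold lower number from compound 3 to compound 4 (0.18 log units; within the scatter). Compound 4 is therefore expected to give about 3500 nM in this assay, with a likely range from 1000 nM to 12000 nM.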

Compound 4, half-maximal inhibitory concentration: 454 nM
Beside the measured number, compound 4's estimate is 7.7-fold (0.89 log units) above it, and the stated range ends above it.
By their numbers in this assay, from the lowest: compound 4; then compound 2; then compound 3. At a limit, above all of these: compound 1.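

In this assay, among these compounds, the change from pyridin-4-yl to 2-(dimethylamino)pyridin-4-yl gives a 12-fold lower number from compound 3 to compound 4 (1.06 log units; beyond the scatter) and this is the first step that can be read from a single change. It shows that this ring carbon, next to the ring nitrogen, is not a silent position: one dimethylamino group placed there moves the number well beyond the usual scatter of repeated measurements, while the amide and the pyrazole stay the same. The earlier compounds shown here differ from one another in more than one place, so they could not tie any shift in the number to a single group on a single ring, whereas this pair can.

On these data alone, it remains open whether the stronger inhibition belongs to dimethylamino in particular or would also come with methylamino, morpholine or a methoxy group on the same carbon, and whether dimethylamino would have a similar effect on another carbon of this ring. Nothing measured here explains why this step is so large.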